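Isatin-type amides: swapping the pendant aryl ring

This account rests on a few compounds, and the source may have more. Where it says the series, first, only, none or still open, it means among the compounds named here.

Measured so far:
compound 1, `COc1ccc(CN2C(=O)C(=O)c3cc(-c4ccc(C(C)(C)C)cc4)ccc32)cc1`, 4580 nM
compound 2, `COc1ccc(CN2C(=O)C(=O)c3cc(-c4ccc(F)c(Cl)c4)ccc32)cc1`, > 10000 nM

In a functional assay on HepG2 cells (Homo sapiens) for antiproliferative activity, read by MTT assay, with a stated time of 48 h (a lower number here means a stronger inhibitor, a higher number a weaker inhibitor), compound 1 gives 4580 nM. For compound 2 the result is a limit of the assay, > 10000 nM, and not a number; it sits at the limit of > 10000 nM in this assay, at which 1 of the 2 values shown sits. Among the measured compounds shown here, the only measured step, an at least 2.1-fold higher number from compound 1 to compound 2 (0.33 log units; beyond the scatter), therefore gives a weaker inhibitor, though of unknown extent.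

Compound 3, `COc1ccc(CN2C(=O)C(=O)c3cc(-c4ccc(C)cc4)ccc32)cc1`, has not yet been tested in this assay. It differs from compound 2 in one place: 4-methylphenyl in place of 3-chloro-4-fluorophenyl on an aromatic carbon. For the measured compounds named here, a 4-methylphenyl group resembles the 4-(tert-butyl)phenyl group of compound 1 more than it does the 3-chloro-4-fluorophenyl group, yet the one measured step gives no number for the size of the change. Compound 3 is thus expected to fall between the two measured compounds, an expected at least 1.4-fold lower number from compound 2 to compound 3 (0.15 log units; that floor lies within the scatter). The estimate for compound 3 is 7000 nM, with a likely range from 3000 nM to 15000 nM.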

Compound 3, half-maximal inhibitory concentration: > 10000 nM
Compound 3: a limit, no number; the forecaster's own chance of this, stated with the estimate: 35%; at least 1.4-fold (0.15 log units) between middle value and limit.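

In this assay compound 3 also gives a limit and not a number, > 10000 nM. Methyl in place of tert-butyl on the aryl ring gives an at least 2.1-fold higher number from compound 1 to compound 3 (0.33 log units; beyond the scatter), so the smaller 4-methylphenyl group yields a weaker inhibitor, though the extent of the loss is unknown. Compound 1, with its 4-(tert-butyl)phenyl group, is now the only one of the three with a number, while the other two sit together at the same limit: the limit of > 10000 nM in this assay, at which 2 of the 3 values shown sit.

The step between compound 2 and compound 3 cannot be read, so the 4-methylphenyl and 3-chloro-4-fluorophenyl groups remain unranked. From the compounds shown here alone, it also remains open whether an isopropyl group, a longer alkyl chain or an amine on this phenyl ring would give a number at all.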